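A few compounds are considered here, and "the series" means these few. Any claim that something is new, unique, unknown or untested is made for them only; others in the source may bear on it.

Working notes on the series. In a functional assay on HeLa cells (Homo sapiens) for cytotoxicity, read by MTT assay (on this read-out lower numbers stand for stronger inhibition and higher numbers for weaker inhibition), compound 1 (`CC(C)=CC[C@@H](OC[C@H](C)O)C1=CC(=O)c2c(O)ccc(O)c2C1=O`) gives 40300 nM, compound 2 (`CC(C)=CC[C@@H](OCCO)C1=CC(=O)c2c(O)ccc(O)c2C1=O`) gives 18600 nM and compound 3 (`CC(C)=CC[C@@H](OC(=O)CC(C)(O)c1ccccc1)C1=CC(=O)c2c(O)ccc(O)c2C1=O`) gives 85700 nM, the highest number of the three. Compound 4 (`CCC(O)(CC)CC(=O)O[C@H](CC=C(C)C)C1=CC(=O)c2c(O)ccc(O)c2C1=O`) has not yet been measured in this assay. Going from compound 3 to compound 4, the change is 1-ethyl-1-hydroxypropyl in place of 1-hydroxy-1-phenylethyl on a saturated chain carbon bound to a carbonyl carbon. Among the measured compounds shown here, the only measured one-place step is a 2.2-fold lower number from compound 1 to compound 2 (0.34 log units; beyond the scatter), hydrogen in place of methyl. For the measured compounds named here, it sits in a different side chain and bears only loosely on this change, and no measured step removes the aromatic ring. It does suggest a modest scale for one-place changes here. Compound 3 at 85700 nM stands at the top of the measured numbers, so a modest move towards a lower number is expected, though one within the scatter would not surprise. The expected step is a 1.7-fold lower number from compound 3 to compound 4 (0.23 log units; within the scatter). Compound 4 is estimated at 50000 nM, with an expected range of 22000 nM to 100000 nM.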

Compound 4, half-maximal inhibitory concentration: 52000 nM
Estimate against measurement, compound 4: 1.0-fold (0.02 log units) below; the measured number falls inside the stated range.
By their numbers in this assay, from the lowest: compound 2; then compounds 1, 4 and 3 (each within the scatter of the next, the first and the last beyond it).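

In this assay, 1-ethyl-1-hydroxypropyl in place of 1-hydroxy-1-phenylethyl on a saturated chain carbon bound to a carbonyl carbon gives a 1.6-fold lower number from compound 3 to compound 4 (0.22 log units; within the scatter) and so shows that the six-membered aromatic ring can leave this place without a step clear of the scatter. The (2-ethyl-2-hydroxybutyl)carbonyl group on an oxygen on a saturated carbon gives a 2.8-fold higher number from compound 2 to compound 4 (0.45 log units; beyond the scatter) when it replaces 2-hydroxyethyl, but a 1.3-fold higher number from compound 1 to compound 4 (0.11 log units; within the scatter) when it replaces 2-hydroxypropyl, so this exchange is resolved against only one of the two side chains. No supporting evidence accounts for these steps.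

From the compounds shown here alone, whether an amine in place of the hydroxyl of 1-ethyl-1-hydroxypropyl would give a step beyond the scatter remains open. The same holds for butyl chains in place of its ethyl groups.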